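Trifluoromethyl in place of nitro: expected antiproliferative potency

This account rests on a few compounds, and the source may have more. Where it says the series, first, only, none or still open, it means among the compounds named here.

For the measured compounds named here, compound 2 `COc1ccc(C(=O)/C=C/c2ccc([N+](=O)[O-])cc2)c2c1C=CC(C)(C)O2` is the only member of the series with a numerical result in a functional assay on HCT-116 cells (Homo sapiens) for antiproliferative activity, read by MTT assay, with a stated time of 24 h (a higher number here means a weaker inhibitor, a lower number a stronger inhibitor), where compound 2 gives 8880 nM. Compound 1 `COc1ccc(C(=O)/C=C/c2ccc(F)cc2)c2c1C=CC(C)(C)O2` reaches only the assay limit, > 10000 nM. Going by the values given here, the single measured step, an at least 1.1-fold lower number from compound 1 to compound 2 (0.05 log units; that floor lies within the scatter), therefore rests on a limit of > 10000 nM in this assay, at which 1 of the 2 values shown sits, and sits within the scatter. Compound 3 `COc1ccc(C(=O)/C=C/c2ccc(C(F)(F)F)cc2)c2c1C=CC(C)(C)O2` differs from compound 2 by trifluoromethyl in place of nitro on an aromatic carbon. Among the compounds with values here, the same position carried the one measured change, which was small, so the step of a 1.1-fold higher number from compound 2 to compound 3 (0.05 log units; within the scatter) is expected to stay within the scatter. Compound 3 is thus estimated at 10000 nM, with a range of 4000 nM to 30000 nM, and a limit report is about as likely as a number.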

Compound 3, half-maximal inhibitory concentration: > 10000 nM
Compound 3 gave a limit, no number (the forecaster's own chance of this, stated with the estimate: 50%); the middle value sits exactly at the limit.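

For the compounds shown here, with trifluoromethyl on this aromatic carbon, compound 3 gives only a limit in this assay, as compound 1 does with fluoro, so nitro in compound 2 remains the only group here with a numerical result. Trifluoromethyl in place of nitro gives an at least 1.1-fold higher number from compound 2 to compound 3 (0.05 log units; that floor lies within the scatter), which does not separate the two groups, and the step between the two limit compounds cannot be read. Most of the series now sits at the limit: the limit of > 10000 nM in this assay, at which 2 of the 3 values shown sit.

From the compounds shown here alone, how far compound 1 and compound 3 lie past the limit remains open. So does what an amine or a carboxylic acid on this aromatic carbon would give.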